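The compounds below may be only part of what the source reports. "The series", "measured", "known", "first", "only" and "open" are said of these compounds alone.

Compound 1 `Nc1scc(CN2CCN(c3ccncc3)CC2)c1C(=O)c1ccc(Cl)cc1` and compound 2 `Nc1scc(CN2CCN(C3CCCCCC3)CC2)c1C(=O)c1ccc(Cl)cc1` share one core and differ only in the group on the amine nitrogen in a ring. In a functional assay on CHO cells with adenosine receptor A1 (Homo sapiens) as the target, read by cAMP accumulation and immunoassay, with a stated time of 6 min, tested at 0.1 uM (on this read-out higher numbers stand for a weaker effect at the one concentration tested and lower numbers for a stronger effect), compound 1 gives 1.4%. In this assay, going by the values given here, compound 2 gives 13%, which is the higher of the two numbers measured so far; the single measured step, a number 11.6 percentage points higher from compound 1 to compound 2 (beyond the scatter), shows that cycloheptyl in place of pyridin-4-yl weakened the effect by a modest margin. Compound 3 `Nc1scc(CN2CCN(c3cccc(F)c3)CC2)c1C(=O)c1ccc(Cl)cc1` is not yet measured; it carries 3-fluorophenyl in place of cycloheptyl on an amine nitrogen in a ring. That measured step is the only one that bears on this change. It suggests that an aromatic ring at this position goes with a stronger effect than cycloheptyl, although 3-fluorophenyl is not pyridin-4-yl, so the size is uncertain. The expected step is a number 7 percentage points lower from compound 2 to compound 3 (within the scatter), a move back toward the number of compound 1. For compound 3 the estimate in this assay is 6%, in a range from 0% to 20%.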

Compound 3, a percentage reported as activity, at one concentration (the size of the read-out at that concentration, not a potency): -37%
The estimate for compound 3 lay 43 percentage points above the measured number; measured number outside the range, below it.
By their numbers in this assay, from the lowest: compound 3; then compound 1; then compound 2.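

In this assay the 3-fluorophenyl group gives a number 50 percentage points lower from compound 2 to compound 3 (beyond the scatter) and also a number 38.4 percentage points lower from compound 1 to compound 3 (beyond the scatter) as one aromatic ring replaces another, so having an aromatic ring on this amine nitrogen does not by itself set the number; which aromatic ring it is matters a great deal. Compound 3 also takes the read-out below zero, which neither earlier compound did. Cycloheptyl and 3-fluorophenyl each have 7 heavy atoms and no hydrogen-bond donors or acceptors, so those counts do not track this large step, and no measurement at hand gives a reason for it.

Whether the fluorine matters stays open, as a plain phenyl group and a 3-chlorophenyl group are not among the compounds shown. With a single tested concentration, the potency of these compounds also remains unknown.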